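Amino to acetamido on a very potent compound

This account rests on a few compounds, and the source may have more. Where it says the series, first, only, none or still open, it means among the compounds named here.

Measured in a functional assay on MCF7 cells (Homo sapiens) for antiproliferative activity; on this read-out higher numbers stand for weaker inhibition and lower numbers for stronger inhibition:
Compound 1 `Cc1cc(-c2nc3ccccc3s2)ccc1N`: < 1 nM, a limit
Compound 2 `Nc1ccc(-c2nc3ccccc3s2)cc1Br`: < 1 nM, a limit

Compound 1 stands at < 1 nM, which is a limit and not a number. Compound 3 `CC(=O)Nc1ccc(-c2nc3ccccc3s2)cc1C` differs from compound 1 by acetyl in place of hydrogen on a nitrogen on an aromatic ring, that is, amino to acetamido. Among the measured compounds shown here, the only measured step, a step that the two limits leave unreadable from compound 1 to compound 2, changes a different group and offers no size to carry over. The data therefore hold no direct guide to this change. For the measured compounds named here, with the limit of < 1 nM in this assay, at which 2 of the 2 values shown sit, a weakening is the only change that could be read in this assay, so a modest one is expected, an at least 2.0-fold higher number from compound 1 to compound 3 (0.30 log units; that floor lies within the scatter). Compound 3 is estimated at 2 nM, with an expected range of 0.4 nM to 40 nM.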

Compound 3, half-maximal inhibitory concentration: > 10000 nM
Compound 3: a limit, no number; the forecaster's own chance of this, stated with the estimate: 40%; at least 5000-fold (3.69 log units) between middle value and limit.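

In this assay, acetyl in place of hydrogen on the nitrogen on the aromatic ring gives an at least 10000-fold higher number from compound 1 to compound 3 (4.00 log units; beyond the scatter), a large step beyond the scatter. Compound 3 stands at > 10000 nM, which is a limit and not a number. Among the compounds shown here, this nitrogen is therefore a highly sensitive place on the shared core of compound 1, which the earlier compounds could not show.

The step from compound 1 to compound 2 cannot be read, so the methyl-to-bromo change has no size. Going by these compounds, whether a methyl or a longer acyl chain on that nitrogen would give the same loss stays open.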